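Methoxyphenyl in Place of Chlorophenyl on a Piperazine Nitrogen

A few compounds are considered here, and "the series" means these few. Any claim that something is new, unique, unknown or untested is made for them only; others in the source may bear on it.

Three compounds built on a shared core have been examined in an ADME assay on MT4 cells (Homo sapiens) for cytotoxicity, read by MTT assay, with a stated time of 5 days; a higher number here means that more compound is tolerated, a lower number that less compound is tolerated. Compound 1 `COc1cc(Cc2cnc(/N=C3\C(=O)N(CN4CCC(C)CC4)c4ccc(Cl)cc43)nc2N)cc(OC)c1OC` gives 67.4 ug/mL in this assay. Compound 2 `COc1cc(Cc2cnc(/N=C3\C(=O)N(CN4CCN(c5ccc(Cl)cc5)CC4)c4ccc(Cl)cc43)nc2N)cc(OC)c1OC` gives 38.6 ug/mL in this assay, the lowest of the three numbers; its gap to compound 1 lies within the usual scatter, so the two cannot be put in order, whereas compound 3 `COc1cc(Cc2cnc(/N=C3\C(=O)N(CN4CCN(c5cc6c(cc5F)c(=O)c(C(=O)O)cn6C5CC5)CC4)c4ccc(Cl)cc43)nc2N)cc(OC)c1OC`, which gives 187 ug/mL in this assay, stands beyond the scatter above compound 2.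

Compound 4 `COc1cccc(N2CCN(CN3C(=O)/C(=N\c4ncc(Cc5cc(OC)c(OC)c(OC)c5)c(N)n4)c4cc(Cl)ccc43)CC2)c1` has not yet been measured. It differs from compound 2 by a single change: 3-methoxyphenyl in place of 4-chlorophenyl on an amine nitrogen in a ring. For the measured compounds named here, no pair of measured compounds isolates this change, so the expectation rests on the three values alone. Two of the three measured compounds sit within the scatter of each other, and only compound 3 is set apart, so the data give no sign that an exchange of one aryl group for another at this position would move the number far. The step is expected to be small, a 1.3-fold higher number from compound 2 to compound 4 (0.11 log units; within the scatter), and not beyond the scatter in either direction. Compound 4 is therefore estimated at 50 ug/mL in this assay, with a range from 25 ug/mL to 100 ug/mL.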

Compound 4, half-maximal cytotoxic concentration: 32.6 ug/mL
Compound 4: the middle estimate sits 1.5-fold (0.19 log units) above what was measured; measured number inside the range.
By their numbers in this assay, from the lowest: compounds 4, 2 and 1 (each within the scatter of the next, the first and the last beyond it); then compound 3.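

In this assay, for the compounds shown here, 3-methoxyphenyl in place of 4-chlorophenyl on the amine nitrogen in the ring gives a 1.2-fold lower number from compound 2 to compound 4 (0.07 log units; within the scatter), the first step in this set to isolate a single change, and it lies within the scatter. This position therefore accepts the exchange of one aryl group for another with no measurable shift in this read-out, even though the entering group brings one hydrogen-bond acceptor and the leaving group brings none and the substituent on the aromatic ring is different in both kind and place. No measurement at hand offers an explanation for this outcome.

The step changes the substituent and its place together, so the compounds shown cannot say how each would act alone; 3-chlorophenyl or 4-methoxyphenyl on the same nitrogen would separate the two. From the compounds shown here alone, it also remains open whether the tolerance seen here extends to an unsubstituted phenyl, a pyridyl ring or a simple alkyl chain at this nitrogen, since both aryl groups compared here are substituted six-membered carbon rings.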